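The source may report more compounds than this note shows. Statements on the series, on what has been measured and on what is new or still open speak of the compounds shown alone.

Measured in a functional assay on HL-60 cells (Homo sapiens) for inhibition, read by MTT assay, with a stated time of 72 h; a lower number here means a stronger inhibitor, a higher number a weaker inhibitor:
- compound 1 `COc1cc(O)c(CC=C(C)C)c(O)c1C(=O)/C=C/c1ccc(C(F)(F)F)cc1`: 5300 nM
- compound 2 `COc1cc(O)cc(O)c1C(=O)/C=C/c1cccc([N+](=O)[O-])c1`: 5900 nM
- compound 3 `COc1cc(OC)c(C(=O)/C=C/c2ccc(C(F)(F)F)cc2)c(OC)c1`: 6500 nM

Compound 3, at 6500 nM, cannot be separated from compound 1 or compound 2, as all three values lie within the scatter. Compound 4 `COc1cc(OC)c(C(=O)/C=C/c2ccc(Cl)cc2)c(OC)c1` carries chloro in place of trifluoromethyl on an aromatic carbon, para to a large group (chloro in place of trifluoromethyl on an aromatic carbon). Among the compounds with values here, no measured pair isolates this exchange, so the data give no direct guide to it. Although they differ structurally from compound 3, compound 1 and compound 2 stay within the scatter of it. The expected change is a 1.1-fold lower number from compound 3 to compound 4 (0.03 log units; within the scatter), a step not expected to exceed the scatter in either direction. Compound 4 is estimated at 6000 nM, with an expected range of 2500 nM to 14000 nM.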

Compound 4, half-maximal inhibitory concentration: 4200 nM
Estimate against measurement, compound 4: 1.4-fold (0.15 log units) above; the measured number falls inside the stated range.
By their numbers in this assay, from the lowest: compounds 4, 1, 2 and 3 (each within the scatter of the next).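

In this assay, within the data shown here, the exchange of trifluoromethyl for chloro on an aromatic carbon, para to a large group, gives a 1.5-fold lower number from compound 3 to compound 4 (0.19 log units; within the scatter) and is the first matched step at this position. At this position the two groups cannot be told apart in this measurement, so the substituent tolerates this one exchange without a step beyond the scatter. Nothing on hand offers an explanation for the step. Open, as far as these compounds go, is whether an amine or a carboxylic acid at this position would give a step beyond the scatter. Also open, from the compounds shown here alone, is whether the same exchange behaves alike on the core of compound 1.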